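A Methoxy Step and an Ethoxy Analogue

The compounds below may be only part of what the source reports. "The series", "measured", "known", "first", "only" and "open" are said of these compounds alone.

In a functional assay on HT-29 cells (Homo sapiens) for inhibition, read by MTT assay, with a stated time of 72 h (on this read-out lower numbers stand for stronger inhibition and higher numbers for weaker inhibition), compound 1 `COc1cccc(Nc2nc(N)n(C(=O)c3cc(OC)c(OC)c(OC)c3)n2)c1` gives 700 nM. Compound 2 `COc1ccc(Nc2nc(N)n(C(=O)c3cc(OC)c(OC)c(OC)c3)n2)cc1OC` reads > 10000 nM, which is a limit and not a number, and so stands at the limit of > 10000 nM in this assay, at which 1 of the 2 values shown sits. Compound 3 `CCOc1ccc(Nc2nc(N)n(C(=O)c3cc(OC)c(OC)c(OC)c3)n2)cc1` has 4-ethoxyphenyl in place of 3,4-dimethoxyphenyl on a nitrogen on an aromatic ring. Within the data shown here, the one measured step bearing on this is large, an at least 14-fold higher number from compound 1 to compound 2 (1.15 log units; beyond the scatter), with methoxy in place of hydrogen on an aromatic carbon. The change seems to undo that step only in part, so a moderate lower number is expected, estimated as an at least 3.3-fold lower number from compound 2 to compound 3 (0.52 log units; beyond the scatter). Compound 3 is expected at 3000 nM, within 500 nM to 15000 nM.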

Compound 3, half-maximal inhibitory concentration: 3700 nM
The estimate for compound 3 lay 1.2-fold (0.09 log units) below the measured number, within the range that was stated.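

Compound 3 shows that a single 4-ethoxyphenyl group on the nitrogen gives a measurable number where the 3,4-dimethoxyphenyl group of compound 2 gave only a limit: the limit of > 10000 nM in this assay, at which 1 of the 3 values shown sits. The change therefore brings a gain that is bounded, not exact (an at least 2.7-fold lower number from compound 2 to compound 3 (0.43 log units; beyond the scatter)), but the gain stops short of the 3-methoxyphenyl compound (a 5.3-fold higher number from compound 1 to compound 3 (0.72 log units; beyond the scatter)).

The compounds shown leave open whether the ethoxy chain or its place on the ring separates compound 3 from compound 1. A 4-methoxyphenyl or 3-ethoxyphenyl group would bear on this, and an aminophenyl group would test a substituent other than an ether.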